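Sulfonamide swap on compound 3

The source may report more compounds than this note shows. Statements on the series, on what has been measured and on what is new or still open speak of the compounds shown alone.

In a functional assay on MCF7 cells (Homo sapiens) for inhibition, read by CCK-8 assay, with a stated time of 72 h (on this read-out lower numbers stand for stronger inhibition and higher numbers for weaker inhibition), compound 1 `O=C(/C=C/c1cccnc1)NCCCc1ccc(S(=O)(=O)Nc2ccccc2)cc1` gives 4120 nM and compound 2 `O=C(/C=C/c1cccnc1)NCCCCCc1ccc(S(=O)(=O)Nc2ccccc2)cc1` gives 95.7 nM. Compound 3 `Cc1ccccc1NS(=O)(=O)c1cccc(CCCCCCNC(=O)/C=C/c2cccnc2)c1` gives 0.226 nM, the lowest of the three numbers and beyond the scatter from both others. Compound 4 `O=C(/C=C/c1cccnc1)NCCCCCCc1cccc(S(=O)(=O)Nc2ccc(Cl)cc2)c1` carries 4-chlorophenyl in place of 2-methylphenyl on a sulfonamide nitrogen. Among the measured compounds shown here, no measured pair isolates this change, so there is no direct precedent for the size of the step. With compound 3 already at 0.226 nM, a rise in this assay beyond the scatter is expected rather than a further fall. The expected move is a 6.6-fold higher number from compound 3 to compound 4 (0.82 log units; beyond the scatter), with wide uncertainty. For compound 4 the estimated value is 1.5 nM, with an expected range of 0.15 nM to 15 nM.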

Compound 4, half-maximal inhibitory concentration: 5.94 nM
Compound 4: the middle estimate sits 4.0-fold (0.60 log units) below what was measured; measured number inside the range.
By their numbers in this assay, from the lowest: compound 3; then compound 4; then compound 2; then compound 1.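

Among the compounds shown here, the sulfonamide nitrogen is a sensitive position in this assay: 4-chlorophenyl in place of 2-methylphenyl gives a 26-fold higher number from compound 3 to compound 4 (1.42 log units; beyond the scatter) and is the first single-place change. The two groups match in heavy-atom count, and each is one six-membered aromatic ring of carbon only, yet the step is large. No measured property bears on this step. Still open, going by these compounds, is whether the step follows the chlorine, its place on the ring, or the loss of the methyl. 4-Methylphenyl or 2-chlorophenyl on the same sulfonamide nitrogen would separate these.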